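Chloro for methyl on the core of compound 2

The source may report more compounds than this note shows. Statements on the series, on what has been measured and on what is new or still open speak of the compounds shown alone.

Of the compounds shown here, two have been measured in an assay for inhibition of 3-hydroxy-3-methylglutaryl-coenzyme A reductase (Rattus norvegicus); a lower number here means a stronger inhibitor, a higher number a weaker inhibitor. Compound 1 `O=C1C[C@H](O)C[C@@H](/C=C/c2c(Cl)cc(Cl)cc2-c2cc(Cl)cc(Cl)c2)O1` gives 37 nM. Compound 2 `Cc1cc(-c2cc(Cl)cc(C)c2/C=C/[C@@H]2C[C@@H](O)CC(=O)O2)ccc1F` gives 6 nM, the lowest of the two numbers; the nearest is that of compound 1, and the gap between them lies beyond the scatter. Compound 3 `Cc1cc(-c2cc(Cl)cc(Cl)c2/C=C/[C@@H]2C[C@@H](O)CC(=O)O2)ccc1F` remains to be measured in this assay. It differs from compound 2 in one place: chloro in place of methyl on an aromatic carbon. Within the data shown here, no step between measured compounds covers this exchange, so its size is open. Compound 1 carries chloro where compound 2 carries methyl and is the weaker of the two, but it differs also in its other ring, so its number cannot be carried over directly. The step of a 1.7-fold higher number from compound 2 to compound 3 (0.22 log units; within the scatter) is expected to be small, leaning toward a slightly higher number, or none beyond the scatter. Compound 3 is estimated at 10 nM, with a range from 4 nM to 30 nM.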

Compound 3, half-maximal inhibitory concentration: 29 nM
For compound 3 the middle estimate is 2.9-fold (0.46 log units) below the measured one; measured number inside the range.
By their numbers in this assay, from the lowest: compound 2; then compounds 3 and 1 (each within the scatter of the next).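

In this assay, chloro in place of methyl on this aromatic carbon, ortho to a large group, gives a 4.8-fold higher number from compound 2 to compound 3 (0.68 log units; beyond the scatter), so this single exchange is enough to take the series away from the low number held by compound 2. With chloro held at this position, 4-fluoro-3-methylphenyl in place of 3,5-dichlorophenyl gives a 1.3-fold lower number from compound 1 to compound 3 (0.11 log units; within the scatter), so on this core that exchange shows no change beyond the scatter. Nothing at hand accounts for either step.

As far as these compounds go, whether the exchange of 3,5-dichlorophenyl for 4-fluoro-3-methylphenyl stays as small with methyl on the core remains open. From the compounds shown here alone, how hydrogen, ethyl or methoxy on this aromatic carbon would compare with methyl and chloro is also open.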